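The source may hold more compounds than are shown below. What is called first, only, known or untested is meant among the compounds shown, and "the series" means these compounds.

Compound 1 `CCOC(=O)C1=C(NN=C(C(C)=O)C(C)=O)Nc2[nH]nc(C)c2C1c1ccc(N(C)C)cc1`: 58700 nM
Compound 2 `CCOC(=O)C1=C(NN=C(C#N)C#N)Nc2[nH]nc(C)c2C1c1ccc(N(C)C)cc1`: 45300 nM
Compound 3 `CCOC(=O)C1=C(N/C=N/c2ncc(-c3ccccc3)s2)Nc2[nH]nc(C)c2C1c1ccc(N(C)C)cc1`: 29500 nM

All three compounds were tested in an ADME assay on WISH cells (Homo sapiens) for cytotoxicity, read by MTT assay, with a stated time of 48 h; a lower number here means a stronger inhibitor, a higher number a weaker inhibitor. Their values lie within the usual scatter of one another, so compound 1 cannot be separated from compound 2 or compound 3.

Compound 4 `CCOC(=O)C1=C(N)Nc2[nH]nc(C)c2C1c1ccc(N(C)C)cc1` has not yet been measured. The change that leads to it is a hydrogen atom in place of a group of 8 heavy atoms (5 carbon, 1 nitrogen, 2 oxygen; no ring), on an amine nitrogen. Among the measured compounds shown here, one measured step bears directly on this site: a 1.3-fold lower number from compound 1 to compound 2 (0.11 log units; within the scatter). It exchanges one group on the amine nitrogen for another. Compound 3, which carries a different group there, gives 29500 nM, still within the scatter of compound 1. None of these compounds shows what happens when the group is removed and only hydrogen remains, so the range must stay wide. No shift beyond the scatter is expected, and the estimated change is a 1.3-fold lower number from compound 1 to compound 4 (0.12 log units; within the scatter). For compound 4 the expected value is 45000 nM, with an estimated range of 18000 nM to 110000 nM.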

Compound 4, half-maximal inhibitory concentration: 94600 nM
For compound 4 the middle estimate is 2.1-fold (0.32 log units) below the measured one; the range from low to high includes it.
By their numbers in this assay, from the lowest: compounds 3, 2, 1 and 4 (each within the scatter of the next, the first and the last beyond it).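

Among the compounds shown here, this is the first result at this position to show a bare amine, with hydrogen alone on the nitrogen instead of a larger group. In this assay the change gives a 1.6-fold higher number from compound 1 to compound 4 (0.21 log units; within the scatter) and so does not separate compound 4 from compound 1. For the compounds shown here, the same change gives a 2.1-fold higher number from compound 2 to compound 4 (0.32 log units; beyond the scatter) as the one step at this position that lies beyond the scatter, so the bare amine of compound 4 is a weaker inhibitor than compound 2, though the size of this step is modest.

From the compounds shown here alone, whether a small group on this nitrogen, such as methyl or acetyl, would give a number closer to compound 2 or to compound 4 remains open. No supporting measurement is available to explain the gap between compound 2 and compound 4.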